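Chain extension in the cinnamate series: compound 3 to compound 4

The source may report more compounds than this note shows. Statements on the series, on what has been measured and on what is new or still open speak of the compounds shown alone.

Of the compounds shown here, three have been measured in a physicochemical assay for lipophilicity, using the shake flask method, measured as octanol-water partition, at pH 7.4; on this read-out higher numbers stand for higher lipophilicity and lower numbers for lower lipophilicity. Compound 1 `COc1cc(/C=C/C(=O)Nc2ccccc2)ccc1OCCCN(C)C` gives 1.55. Compound 2 `CCN(CC)CCCCCCCCCCOc1ccc(/C=C/C(=O)Nc2ccccc2)cc1OC` gives 1.83. Compound 3 `CCOC(=O)/C=C/c1ccc(OCCCCCCN(CC)CC)c(OC)c1`, the ethyl ester, gives 1.8. Compound 3 sits within the usual scatter of both other compounds, with compound 2 the nearer and compound 1 the further of the two, so the three measured values do not separate from one another in this assay.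

Compound 4 `CCOC(=O)/C=C/c1ccc(OCCCCCCCCN(CC)CC)c(OC)c1` has not yet been measured. It differs from compound 3 by one change: 2-(diethylamino)ethyl in place of diethylamino on a saturated chain carbon, six bonds along the chain from an oxygen on an aromatic ring. Within the data shown here, no measured pair isolates this change, so any expectation rests on the chain growing by two saturated carbons with nothing else altered. On this assay such a change is expected to move the value upward, by a step that should exceed the scatter but stay modest, given how little the measured compounds differ across chains of very different length. The step from compound 3 to compound 4 is estimated at a number 0.40 log units higher from compound 3 to compound 4 (beyond the scatter). Compound 4 is therefore expected to give about 2.2, in a range from 1.8 to 2.7.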

Compound 4, partition coefficient: 1.98
The estimate for compound 4 lay 0.22 log units above the measured number, and the stated range covers the measured number.
By their numbers in this assay, from the lowest: compounds 1, 3, 2 and 4 (each within the scatter of the next, the first and the last beyond it).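

In this assay, among these compounds, the one pair differing in a single place reads a number 0.18 log units higher from compound 3 to compound 4 (within the scatter) and so does not separate the two compounds. At this position on the ester, then, 2-(diethylamino)ethyl in place of diethylamino gives a number that cannot be told apart from that of compound 3, even with the added chain carbons; this holds for this single pair only and sets no trend along the chain. Nothing available here bears on why the step has this size.

From the compounds shown here alone, whether a longer chain on the ester would give a step beyond the scatter remains open, as does the outcome of a morpholine in place of diethylamino at the chain end. Going by these compounds, how a carboxylic acid in place of the ethyl ester, or the amide of compound 1 and compound 2, compares with the ester on an otherwise unchanged chain also stays open.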